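The source may report more compounds than this note shows. Statements on the series, on what has been measured and on what is new or still open speak of the compounds shown alone.

Measured in a functional assay (muscle tissue) with Cavia porcellus as the target; a lower number here means that less compound is needed, a higher number that more compound is needed for the effect:
- compound 1 `COC(=O)C1=C(C)N=C(C)/C(=C(\O)OC)C1c1ccccc1Cl`: 2.19 nM
- compound 2 `C=Cc1ccccc1C1C(C(=O)OC)=C(C)N=C(C)/C1=C(\O)OC`: 4.47 nM
- compound 3 `COC(=O)C1=C(C)N=C(C)/C(=C(\O)OC)C1c1c(Cl)cccc1Cl`: 1.91 nM

Compound 3 has the lowest number of the three, but this separates it clearly from only one of the others. The step of a 1.1-fold lower number from compound 1 to compound 3 (0.06 log units; within the scatter) leaves it level, while a 2.3-fold lower number from compound 2 to compound 3 (0.37 log units; beyond the scatter) is a modest gap.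

Compound 4 `COC(=O)C1=C(C)N=C(C)/C(=C(\O)OC)C1c1ccccc1C` carries 2-methylphenyl in place of 2,6-dichlorophenyl on a saturated ring carbon. For the measured compounds named here, no measured step involves a methyl group, so the reading is indirect. Going by the values given here, two steps bear on the change. The step of a 1.1-fold lower number from compound 1 to compound 3 (0.06 log units; within the scatter) concerns the second chloro group and suggests that its absence alone should shift this assay little. The step of a 2.0-fold higher number from compound 1 to compound 2 (0.31 log units; beyond the scatter), with vinyl in place of chloro, is modest and points to a higher number when the remaining chloro gives way to a carbon group. Vinyl is only a partial guide to methyl, and three compounds give thin support.

The expected change is a 1.8-fold higher number from compound 3 to compound 4 (0.25 log units; within the scatter), a small move towards a higher number that is not expected to clear the scatter. For compound 4 the estimated value is 3.4 nM, with an expected range of 1.5 nM to 8 nM.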

Compound 4, half-maximal effective concentration: 6.03 nM
Compound 4: the middle estimate sits 1.8-fold (0.25 log units) below what was measured, and the stated range covers the measured number.
By their numbers in this assay, from the lowest: compounds 3 and 1 (each within the scatter of the next); then compounds 2 and 4 (each within the scatter of the next).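

In this assay, a methyl group on the aromatic ring can now be read directly: a 2.8-fold higher number from compound 1 to compound 4 (0.44 log units; beyond the scatter) shows that methyl in place of chloro on this aromatic carbon clears the scatter, and a 3.2-fold higher number from compound 3 to compound 4 (0.50 log units; beyond the scatter) is a modest step of the same kind for the full change from 2,6-dichlorophenyl to 2-methylphenyl. For the compounds shown here, the two carbon groups are not separated from each other, as a 1.3-fold higher number from compound 2 to compound 4 (0.13 log units; within the scatter) stays within the scatter, so in these four compounds both compound 2 and compound 4 stand apart from the chloro-bearing compound 1 and compound 3, with no compound going against this. Nothing available gives a reason for this gap between chloro and the carbon groups at this position.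

On these data alone, it remains open whether the gap is specific to chloro or extends to other groups on this aromatic carbon, such as fluoro, methoxy or an amine. As far as these compounds go, it is also open whether a second methyl group, as in 2,6-dimethylphenyl, would leave the number as unchanged as the second chloro group does.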